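The source may report more compounds than this note shows. Statements on the series, on what has been measured and on what is new or still open speak of the compounds shown alone.

In a functional assay on HCT-116 cells (Homo sapiens) for antiproliferative activity (a higher number here means that more compound is needed for the effect, a lower number that less compound is needed), compound 3 `Cc1c2c(n3c1CC(=O)NCC[C@H](C)Nc1cc-3ccc1C(N)=O)CC(C)(C)CC2=O` gives 815 nM as the higher of the two numbers available. Compound 1 `Cc1c2c(n3c1CCN(C(=O)[C@H](C)N)CC[C@H](C)Nc1cc-3ccc1C(N)=O)CC(C)(C)CC2=O` gives 314 nM on the same read-out, a lower number by a gap beyond the usual scatter. Compound 2 `Cc1c2c(n3c1CC(=O)NCCCNc1cc-3ccc1C(N)=O)CC(C)(C)CC2=O` has "not determined" (no result reported) as its entry and so offers no comparison. Compound 4 `CC(=O)NCCN1CC[C@H](C)Nc2cc(ccc2C(N)=O)-n2c(c(C)c3c2CC(C)(C)CC3=O)CC1=O` departs from compound 3 at a single place: 2-acetamidoethyl in place of hydrogen on an amide-type nitrogen in a ring describes how 2-acetamidoethyl stands in place of hydrogen on an amide-type nitrogen in a ring. Within the data shown here, no measured pair isolates this kind of change, so the expectation rests on thin ground and its range is kept wide. The estimated step of a 1.4-fold lower number from compound 3 to compound 4 (0.13 log units; within the scatter) is expected to stay within the scatter, with only a slight lean toward a lower number. Compound 4 is expected at 600 nM with an estimated range of 200 nM to 1800 nM in this assay once it is measured.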

Compound 4, half-maximal effective concentration: > 5000 nM
Compound 4: a limit, no number (the forecaster's own chance of this, stated with the estimate: 5%); middle value at least 8.3-fold (0.92 log units) from the limit.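

Compound 4 gives the series its first step at a single place, and it shows that this amide-type nitrogen in a ring does not accept every substituent in this assay. Setting 2-acetamidoethyl in place of hydrogen there gives an at least 6.1-fold higher number from compound 3 to compound 4 (0.78 log units; beyond the scatter), a clear loss of activity that the earlier compounds could not reveal, as no measured pair among them isolated this position. The entry for compound 4 is a limit and not a number: the limit of > 5000 nM in this assay, at which 1 of the 4 values shown sits.

The compounds shown leave open whether a methyl on this nitrogen, or a 2-aminoethyl chain ending in a free amine, would stay close to compound 3 or fall away like compound 4. They also cannot separate the effect of the ethyl chain from that of the acetamide at its end.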